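The source may report more compounds than this note shows. Statements on the series, on what has been measured and on what is new or still open speak of the compounds shown alone.

Measured in an ADME assay on HepG2 cells (Homo sapiens) for cytotoxicity, read by MTT assay, with a stated time of 24 h; on this read-out lower numbers stand for stronger inhibition and higher numbers for weaker inhibition:
Compound 1 `CCOS(=O)(=O)/C=C/c1ccc(OCC2=CC[C@@H]3C(C(=O)Nc4ccc(Oc5ccccc5)cc4)=CO[C@@H](OC)[C@H]23)cc1`: > 200000 nM (a limit)
Compound 2 `CCOS(=O)(=O)/C=C/c1ccc(OCC2=CC[C@@H]3C(C(=O)Nc4ccc(Oc5ccc(Br)cc5Cl)cc4)=CO[C@@H](OC)[C@H]23)cc1`: > 200000 nM (a limit)
Compound 3 `CCOS(=O)(=O)/C=C/c1ccc(OCC2=CC[C@@H]3C(C(=O)Nc4ccc(Oc5ccccc5)cc4)=CO[C@@H](OCc4ccccc4)[C@H]23)cc1`: > 200000 nM (a limit)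

None of these three results is a number, as the limit of > 200000 nM in this assay, at which 3 of the 3 values shown sit, makes plain. Compound 3 reads > 200000 nM, and this is a limit of this assay.

Compound 4 `CCOS(=O)(=O)/C=C/c1ccc(OCC2=CC[C@@H]3C(C(=O)Nc4ccc(Oc5ccc(Br)cc5Cl)cc4)=CO[C@@H](OCc4ccccc4)[C@H]23)cc1` departs from compound 3 in one place: 4-bromo-2-chlorophenyl in place of phenyl on an oxygen on an aromatic ring. The exchange is 4-bromo-2-chlorophenyl in place of phenyl on an oxygen on an aromatic ring. This same exchange has one measured precedent, a step that the two limits leave unreadable from compound 1 to compound 2, so neither a size nor a direction carries over to compound 4, and no step beyond the scatter is expected in this assay. Among the measured compounds shown here, the only other measured step, a step that the two limits leave unreadable from compound 1 to compound 3, concerns a different place in the molecule and adds no readable size either. Compound 4 is therefore expected to be reported as a limit again, like the three compounds before it. The expected step is a step that the limit leaves unreadable from compound 3 to compound 4. For compound 4 the estimated value is 220000 nM, with an expected range from 110000 nM to 400000 nM.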

Compound 4, half-maximal inhibitory concentration: > 200000 nM
Compound 4 gave a limit, no number; the forecaster's own chance of this, stated with the estimate: 90%; the middle value does not contradict the limit.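

In this assay compound 4 gives > 200000 nM, which is a limit and not a number. No step can be read from compound 3 to compound 4 or from compound 2 to compound 4, because every result rests on the same limit: the limit of > 200000 nM in this assay, at which 4 of the 4 values shown sit.

The compounds shown leave open whether either exchange alters cytotoxicity at all, and by how much.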